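Swapping the group on the carbonyl carbon

This account rests on a few compounds, and the source may have more. Where it says the series, first, only, none or still open, it means among the compounds named here.

Compound 1 `Cc1ccc(CNC(=O)c2nn(-c3ccc(F)cc3)c(CC[C@@H](O)C[C@@H](O)CC(=O)O)c2C(C)C)cc1`: 800 nM
Compound 2 `CC(C)c1c(C(=O)N2CCC[C@H](c3ccccc3)C2)nn(-c2ccc(F)cc2)c1CC[C@@H](O)C[C@@H](O)CC(=O)O`: 310 nM

In a functional assay on L6 cells (Rattus norvegicus) for inhibition (a lower number here means a stronger inhibitor, a higher number a weaker inhibitor), compound 2 holds the lower of the two numbers, 310 nM. Compound 3 `CC(C)c1c(C(=O)N(C)Cc2cccc(F)c2)nn(-c2ccc(F)cc2)c1CC[C@@H](O)C[C@@H](O)CC(=O)O` is still unmeasured and differs from compound 2 on the carbonyl carbon: (3-fluorobenzyl)(methyl)amino in place of 3-phenylpiperidin-1-yl on a carbonyl carbon. For the measured compounds named here, one measured step bears on this change, a 2.6-fold lower number from compound 1 to compound 2 (0.41 log units; beyond the scatter), and it is modest. The entering group holds a benzyl, like the (4-methylbenzyl)amino of compound 1 at 800 nM, so a small step towards a higher number is expected, possibly none beyond the scatter. Compound 3 is estimated at 480 nM, within a range of 160 nM to 1400 nM. This estimate means an expected 1.5-fold higher number from compound 2 to compound 3 (0.19 log units; within the scatter).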

Compound 3, half-maximal inhibitory concentration: 1900 nM
Compound 3: middle estimate off by 4.0-fold (0.60 log units), on the low side; the whole stated range lies below it.
By their numbers in this assay, from the lowest: compound 2; then compound 1; then compound 3.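

Having a benzyl in the entering group does not keep the number close to that of compound 1 or compound 2 in this assay: there is a 6.1-fold higher number from compound 2 to compound 3 (0.79 log units; beyond the scatter) and also a 2.4-fold higher number from compound 1 to compound 3 (0.38 log units; beyond the scatter). Compound 3 therefore holds the highest number of the three, and the group on the carbonyl carbon can move the number in either direction. Nothing available gives a reason for this.

The compounds shown do not separate the effect of the methyl on the amide nitrogen from that of the fluorine on the ring. From the compounds shown here alone, how a morpholine on the carbonyl carbon would compare also stays open.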